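The compounds below may be only part of what the source reports. "The series", "measured", "known", "first", "only" and "open" are said of these compounds alone.

Compound 1 `COc1cc(-n2c(-c3ccc(Cl)cc3)csc2=S)cc(OC)c1OC` gives only a limit in a functional assay on MDA-MB-231 cells (Homo sapiens) for cytotoxicity, read by MTT assay, with a stated time of 48 h (a lower number here means a stronger inhibitor, a higher number a weaker inhibitor), namely > 100 ug/mL. Compound 2 `COc1cc(-n2c(-c3ccc(O)cc3)csc2=S)cc(OC)c1OC` gives 22.9 ug/mL in this assay. For the measured compounds named here, the one measured step that bears on the question is an at least 4.3-fold lower number from compound 1 to compound 2 (0.64 log units; beyond the scatter), whose size is bounded by the limit of > 100 ug/mL in this assay, at which 1 of the 2 values shown sits. Compound 3 `COc1ccc(-c2csc(=S)n2-c2cc(OC)c(OC)c(OC)c2)cc1` differs from compound 1 by methoxy in place of chloro on an aromatic carbon. The measured step replaces the chloro with a hydroxy rather than a methoxy, so for compound 3 a move in the same direction but of smaller and less certain size is expected, an at least 1.6-fold lower number from compound 1 to compound 3 (0.22 log units; that floor lies within the scatter). Compound 3 is accordingly estimated at 60 ug/mL, within 20 ug/mL to 150 ug/mL, with a fair chance that only a limit is again reported.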

Compound 3, half-maximal inhibitory concentration: 53.8 ug/mL
Beside the measured number, compound 3's estimate is 1.1-fold (0.05 log units) above it; measured number inside the range.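

Going by these compounds, at this position in this assay, methoxy in place of chloro gives an at least 1.8-fold lower number from compound 1 to compound 3 (0.26 log units; that floor lies within the scatter), so its true size remains unknown and its floor does not by itself separate the two compounds: the limit of > 100 ug/mL in this assay, at which 1 of the 3 values shown sits. The new comparison with the free hydroxy gives a 2.3-fold higher number from compound 2 to compound 3 (0.37 log units; beyond the scatter), showing that methyl on that oxygen moves the number upward beyond the scatter. Among these three compounds, compound 2 therefore remains the most potent.

The compounds shown leave open how an amine, a carboxylic acid or a longer chain such as ethoxy would read at this position.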